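A few compounds are considered here, and "the series" means these few. Any claim that something is new, unique, unknown or untested is made for them only; others in the source may bear on it.

Measured in a toxicity assay on GES1 cells (Homo sapiens) for inhibition, read by MTT assay, with a stated time of 72 h; on this read-out higher numbers stand for weaker inhibition and lower numbers for stronger inhibition:
- compound 1 `C[C@@H]1CCN(c2cc(-c3ccccc3)nc3ncnn23)C[C@@H]1N(C)c1ncnc2[nH]ccc12`: > 100000 nM (a limit of the assay)
- compound 2 `Cc1cc(N2CC[C@@H](C)[C@@H](N(C)c3ncnc4[nH]ccc34)C2)n2nc(SCCc3ccccc3)nc2n1`: 66200 nM
- compound 3 `CCCCCc1c(C)nc2nc(SCc3ccc(Cl)cc3)nn2c1N1CC[C@@H](C)[C@@H](N(C)c2ncnc3[nH]ccc23)C1`: > 100000 nM (a limit of the assay)

For the measured compounds named here, compound 2, at 66200 nM, is the only compound in this set with an actual number. The rest of the set is described by the limit of > 100000 nM in this assay, at which 2 of the 3 values shown sit. Going by the values given here, the read-out therefore offers one numerical anchor and no measured step.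

Compound 4 `CCCSc1nc2nc(C)cc(N3CC[C@@H](C)[C@@H](N(C)c4ncnc5[nH]ccc45)C3)n2n1` is still to be measured in this assay. It differs from compound 2 by methyl in place of phenyl on a saturated chain carbon, two bonds along the chain from a sulfur. In words, this is methyl in place of phenyl on a saturated chain carbon, two bonds along the chain from a sulfur, so phenethylsulfanyl becomes propylsulfanyl.

Among the compounds with values here, no two measured compounds differ in one place, so the size of this change has no direct precedent here. The expectation is a small step toward weaker inhibition, possibly no larger than the usual scatter. It rests on compound 2 at 66200 nM as the starting point. A result reported only as a limit would also be unsurprising for compound 4.

For compound 4 the estimated value is 85000 nM, with an expected range from 40000 nM to 160000 nM.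

The estimate corresponds to an expected step of a 1.3-fold higher number from compound 2 to compound 4 (0.11 log units; within the scatter).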

Compound 4, half-maximal inhibitory concentration: 67100 nM
For compound 4 the middle estimate is 1.3-fold (0.10 log units) above the measured one, within the range that was stated.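

In this assay, for the compounds shown here, the exchange of phenethylsulfanyl for propylsulfanyl supplies the only readable step in the set, a 1.0-fold higher number from compound 2 to compound 4 (0.01 log units; within the scatter), which lies within the scatter. On a saturated chain carbon, two bonds along the chain from a sulfur, methyl in place of phenyl therefore leaves the read-out unchanged within the scatter in this one pair, so the six-membered aromatic ring of phenethylsulfanyl is not required for a numerical value in this assay. Compound 4 is the second compound with an actual number, whereas compound 1 and compound 3 each remain at a limit of the assay and not at a number: the limit of > 100000 nM in this assay, at which 2 of the 4 values shown sit.

Steps involving compound 1 or compound 3 cannot be read, so this single pair shows no trend beyond compound 2 and compound 4. From the compounds shown here alone, it remains open whether a sulfur-linked chain ending in an amine or a carboxylic acid, or a longer alkyl chain such as hexylsulfanyl, would give a step beyond the scatter in this assay.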